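Naphthalene for indole in a macrocyclic motilin ligand

The compounds below may be only part of what the source reports. "The series", "measured", "known", "first", "only" and "open" are said of these compounds alone.

Measured so far:
compound 1, `CCC[C@@H]1NC(=O)[C@@H](C(C)C)NC(=O)[C@@H](CC2CCCCC2)NCCOc2ccccc2CCCNC1=O`, 3250 nM
compound 2, `CCC[C@@H]1NC(=O)[C@@H](C(C)C)NC(=O)[C@@H](Cc2c[nH]c3ccccc23)NCCOc2ccccc2CCCNC1=O`, 255 nM

Of the compounds shown here, two have been measured in an assay on isolated protein for displacement of a labelled ligand from Motilin receptor (Homo sapiens); a higher number here means a weaker inhibitor, a lower number a stronger inhibitor. Within the data shown here, compound 1 gives 3250 nM, while compound 2 gives 255 nM, the lower of the two numbers; the single step recorded, a 13-fold lower number from compound 1 to compound 2 (1.11 log units; beyond the scatter), is large and lies beyond the scatter.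

Compound 3, `CCC[C@@H]1NC(=O)[C@@H](C(C)C)NC(=O)[C@@H](Cc2cccc3ccccc23)NCCOc2ccccc2CCCNC1=O`, has not yet been measured. It differs from compound 2 in one place: naphthalen-1-yl in place of 1H-indol-3-yl on a saturated chain carbon bound to a saturated ring carbon.

Among the measured compounds shown here, the only step available bears on this position: replacing a saturated ring with an aromatic bicycle gave the large gain seen from compound 1 to compound 2. Compound 3 keeps an aromatic bicycle of the same size at that position, so no loss of that magnitude is anticipated; what cannot be read from the two measured compounds is whether the hydrogen-bond donor of the indole contributed. The estimate for compound 3 in this assay is therefore placed modestly above compound 2, as a 2.0-fold higher number from compound 2 to compound 3 (0.29 log units; within the scatter), expected to fall within the scatter or slightly beyond it. Compound 3 is expected to give 500 nM, with a likely range from 150 nM to 2000 nM.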

Compound 3, inhibition constant: 8.3 nM
Compound 3: the middle estimate sits 60-fold (1.78 log units) above what was measured; measured number below the stated range.
By their numbers in this assay, from the lowest: compound 3; then compound 2; then compound 1.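

In this assay, the swap of 1H-indol-3-yl for naphthalen-1-yl on a saturated chain carbon bound to a saturated ring carbon gives a 31-fold lower number from compound 2 to compound 3 (1.49 log units; beyond the scatter) and shows that these two aromatic bicycles are far from interchangeable at this place. The group that enters carries no hydrogen-bond donor and the group that leaves carries one, so a low number at this position does not require such a donor on this group, and the full change from the saturated ring gives a 390-fold lower number from compound 1 to compound 3 (2.59 log units; beyond the scatter) and leaves compound 3 as the strongest of the three in this assay. No measurement at hand explains why naphthalen-1-yl outdoes the indole here.

From the compounds shown here alone, the step from compound 2 to compound 3 changes the ring atoms, the heavy-atom count and the donor count all at once, so the share of each remains unknown, and a benzothiophen-3-yl or benzofuran-3-yl group at the same place would bear on that. Also open, going by these compounds, is whether the point of attachment matters, as with naphthalen-2-yl, and whether a methoxy group or a fluorine on the naphthalene would keep or lower the number.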